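Aryl exchange on the ring nitrogen: compound 3 to compound 4

The source may report more compounds than this note shows. Statements on the series, on what has been measured and on what is new or still open speak of the compounds shown alone.

Compounds 1, 2 and 3 share one core and differ only in the aryl group on the ring nitrogen. In an assay on CHO cells for displacement of a labelled ligand from adenosine receptor A1 (Homo sapiens), read by scintillation counting, with a stated time of 120 min, tested at 10 uM (a lower number here means less inhibition, a higher number more inhibition at the concentration tested (going by the name of the read-out)), compound 1 `Nc1scc(CN2CCN(c3ccc(OC(F)(F)F)cc3)CC2)c1C(=O)c1ccc(Cl)cc1` gives 0%, compound 2 `Nc1scc(CN2CCN(c3ccc(F)cc3F)CC2)c1C(=O)c1ccc(Cl)cc1` gives 1% and compound 3 `Nc1scc(CN2CCN(c3cccc(Cl)c3)CC2)c1C(=O)c1ccc(Cl)cc1` gives 0%. Compound 3 is level with compound 1 at the digits reported, together the lowest of the three, and the three steps are a number 1 percentage points higher from compound 1 to compound 2 (within the scatter), no change at the digits printed from compound 1 to compound 3 (within the scatter) and a number 1 percentage points lower from compound 2 to compound 3 (within the scatter), all within the scatter. Compound 4 `Nc1scc(CN2CCN(c3ccccc3Cl)CC2)c1C(=O)c1ccc(Cl)cc1` differs from compound 3 as follows: 2-chlorophenyl in place of 3-chlorophenyl on an amine nitrogen in a ring. Going by the values given here, no measured step moves a chlorine within the same aryl ring, but every aryl exchange measured so far left this assay flat, so the expected step is a number 1 percentage points higher from compound 3 to compound 4 (within the scatter), none beyond the scatter. Compound 4 is therefore estimated at 1%, within -8% to 12%.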

Compound 4, a percentage reported as inhibition, at one concentration (the size of the read-out at that concentration, not a potency): 2%
Estimate against measurement, compound 4: 1 percentage points below, and the stated range covers the measured number.
By their numbers in this assay, from the lowest: compounds 1, 3, 2 and 4 (each within the scatter of the next).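

Moving the chlorine within the aryl group is a new kind of change at this position, and in this assay it leaves the reading flat (a number 2 percentage points higher from compound 3 to compound 4 (within the scatter)). The 2-chlorophenyl group also reads level with the other aryl groups on the amine nitrogen in a ring (a number 1 percentage points higher from compound 2 to compound 4 (within the scatter); a number 2 percentage points higher from compound 1 to compound 4 (within the scatter)), so all four compounds read alike at the concentration tested. No evidence bearing on this flat reading is at hand.

Open, from the compounds shown here alone, is whether an amine or a carboxylic acid on the aryl group would give a reading beyond the scatter. Also open, going by these compounds, is whether a benzyl group in place of the aryl group on this nitrogen would do so.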